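Replacing nitro with carboxy in compound 1

The source may hold more compounds than are shown below. What is called first, only, known or untested is meant among the compounds shown, and "the series" means these compounds.

Compound 1 `Nc1n[nH]c(N)c1/N=N/c1ccc([N+](=O)[O-])cc1`: 71000 nM
Compound 2 `Nc1n[nH]c(N)c1/N=N/c1ccccc1O`: > 100000 nM (a limit, not a number)

Going by the values given here, in a functional assay on K562 cells (Homo sapiens) for antiproliferative activity (a higher number here means a weaker inhibitor, a lower number a stronger inhibitor), compound 1 gives 71000 nM, the only actual number so far. Compound 2 reaches only a limit of the assay, > 100000 nM. Compound 3 `Nc1n[nH]c(N)c1/N=N/c1ccc(C(=O)O)cc1` has not yet been measured. It differs from compound 1 by carboxy in place of nitro on an aromatic carbon. Among the compounds with values here, no measured step covers this change, so only a modest weakening is expected in this assay. The expected change is a 1.3-fold higher number from compound 1 to compound 3 (0.10 log units; within the scatter). For compound 3 the estimated value is 90000 nM, with an expected range of 40000 nM to 200000 nM.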

Compound 3, half-maximal inhibitory concentration: > 100000 nM
Compound 3 was reported as a limit (the forecaster's own chance of this, stated with the estimate: 45%); at least 1.1-fold (0.04 log units) between middle value and limit.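

In this assay compound 3 gives > 100000 nM, a limit of the assay and not a number. Carboxy in place of nitro on this aromatic carbon, para to a group of 9 heavy atoms, gives an at least 1.4-fold higher number from compound 1 to compound 3 (0.14 log units; that floor lies within the scatter), so this change brings no gain at this position. How much is lost cannot be read, because the reading ends at the assay's limit: the limit of > 100000 nM in this assay, at which 2 of the 3 values shown sit.

As far as these compounds go, whether an amine or a methyl ester in place of nitro at this position would give an actual number remains open.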